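A further step along the chain

The source may report more compounds than this note shows. Statements on the series, on what has been measured and on what is new or still open speak of the compounds shown alone.

Compound 1 `C=COC(=O)[C@H](CC(C)C)NC(=O)[C@H](CO)NC(=O)[C@@H](NC(=O)CCCCCNC(=O)OCc1ccccc1)C(C)C`: > 6 h
Compound 2 `C=COC(=O)[C@H](CC(C)C)NC(=O)[C@H](CO)NC(=O)[C@@H](NC(=O)CCCCCCNC(=O)OCc1ccccc1)C(C)C`: > 6 h

In an ADME assay on a cell-free system (plasma, Homo sapiens) for metabolic stability, with Plasma (Rattus norvegicus) as the target (on this read-out higher numbers stand for a longer-lived compound and lower numbers for a shorter-lived compound), compound 2 stands at > 6 h, which is a limit and not a number. Compound 1 gives > 6 h, also a limit. Compound 3 `C=COC(=O)[C@H](CC(C)C)NC(=O)[C@H](CO)NC(=O)[C@@H](NC(=O)CCCCCCCNC(=O)OCc1ccccc1)C(C)C` has ((benzyloxycarbonyl)amino)methyl in place of (benzyloxycarbonyl)amino on a saturated chain carbon, six bonds along the chain from a carbonyl carbon. Going by the values given here, the one measured step that bears on this is a step that the two limits leave unreadable from compound 1 to compound 2, and it offers no size to carry over. Both known results sit at one limit, (the limit of > 6 h in this assay, at which 2 of the 2 values shown sit). No step beyond the scatter is therefore expected in this assay, in either direction. The expected step is a step that the limit leaves unreadable from compound 2 to compound 3. Compound 3 is estimated at 8 h, with an expected range of 6 h to 16 h.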

Compound 3, half-life: > 6 h
Compound 3 was reported as a limit (the forecaster's own chance of this, stated with the estimate: 85%); the middle value does not contradict the limit.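

In this assay, no step can be read from compound 2 to compound 3, since both results are limits: the limit of > 6 h in this assay, at which 3 of the 3 values shown sit.

As far as these compounds go, the actual half-lives of compound 1, compound 2 and compound 3, and whether lengthening the chain changes them, remain open.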